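Aryl swap on the sulfonyl of the shared core

The compounds below may be only part of what the source reports. "The series", "measured", "known", "first", "only" and "open" are said of these compounds alone.

Compound 1 `Cc1ccc(S(=O)(=O)c2cnc3ccc(Cl)cc3c2N2CCC(C)CC2)cc1C` gives 84% in an assay on isolated protein for displacement of a labelled ligand from metabotropic glutamate receptor 5 (Homo sapiens), with a stated time of 60 min, tested at 1 uM; a lower number here means less inhibition, a higher number more inhibition at the concentration tested (going by the name of the read-out); compound 2 `Cc1ccc2ncc(S(=O)(=O)c3ccc(C)c(C)c3)c(N3CCC(C)CC3)c2c1` gives 90% in this assay. Among the compounds with values here, these are the only two numbers recorded, and the step of a number 6 percentage points higher from compound 1 to compound 2 (within the scatter), a methyl in place of chloro on an aromatic carbon, leaves them standing together. Compound 3 `COc1ccc(S(=O)(=O)c2cnc3ccc(Cl)cc3c2N2CCC(C)CC2)cc1Cl` is not yet measured. It differs from compound 1 on the sulfonyl sulfur whose other neighbour is an aromatic carbon: 3-chloro-4-methoxyphenyl in place of 3,4-dimethylphenyl on a sulfonyl sulfur. Within the data shown here, no measured step touches the group on the sulfonyl sulfur; the single step recorded changes a substituent of the core and stayed within the scatter, so it offers only indirect guidance. Compound 3 is therefore expected to stay near compound 1, with the step of a number 4 percentage points lower from compound 1 to compound 3 (within the scatter) expected to fall within the scatter. The estimate for compound 3 in this assay is 80%, ranging from 60% to 95%.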

Compound 3, a percentage reported as inhibition, at one concentration (the size of the read-out at that concentration, not a potency): 46%
Compound 3: the middle estimate sits 34 percentage points above what was measured, outside the stated range (below it).
By their numbers in this assay, from the lowest: compound 3; then compounds 1 and 2 (each within the scatter of the next).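

Within the data shown here, on the sulfonyl sulfur, the group matters in this assay: 3-chloro-4-methoxyphenyl in place of 3,4-dimethylphenyl gives the first step beyond the scatter (a number 38 percentage points lower from compound 1 to compound 3 (beyond the scatter)), whereas the only earlier step, on the core (a number 6 percentage points higher from compound 1 to compound 2 (within the scatter)), stayed within it. The two aryl groups differ in both substituents at once, and the entering group brings a chlorine and an oxygen, so this single step cannot be assigned to either substituent alone. Nothing available explains the size of this step.

Which of the two substituents carries the step remains open, as does the standing of an unsubstituted phenyl or a pyridyl group on the sulfonyl sulfur. Also open, from the compounds shown here alone, is whether the step keeps its size on the methyl-bearing core of compound 2.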